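Swapping Bromo for Acetyl in a Receptor Binding Series

This account rests on a few compounds, and the source may have more. Where it says the series, first, only, none or still open, it means among the compounds named here.

Three compounds have been measured in an assay on LM cells for displacement of a labelled ligand from Neuropeptide Y receptor type 5 (Homo sapiens); on this read-out lower numbers stand for stronger inhibition and higher numbers for weaker inhibition:

Compound 1, `Fc1ccc(C2(c3ccc(F)cc3)CNC(c3ccccc3)=N2)cc1`: 32 nM
Compound 2, `Fc1ccc(C2(c3ccc(F)cc3)CNC(c3ccc(C(F)(F)F)cc3)=N2)cc1`: 160 nM
Compound 3, `Fc1ccc(C2(c3ccc(F)cc3)CNC(c3cccc(Br)c3)=N2)cc1`: 4.8 nM

Compound 3 gives the lowest number of the three. The step of a 6.7-fold lower number from compound 1 to compound 3 (0.82 log units; beyond the scatter) came with bromo in place of hydrogen on an aromatic carbon, whereas a 5.0-fold higher number from compound 1 to compound 2 (0.70 log units; beyond the scatter) went the other way with trifluoromethyl in place of hydrogen on an aromatic carbon. Compound 4, `CC(=O)c1cccc(C2=NC(c3ccc(F)cc3)(c3ccc(F)cc3)CN2)c1`, differs from compound 3 by acetyl in place of bromo on an aromatic carbon. Within the data shown here, no measured step exchanges bromo for another group at this place; the two steps show only that one added group helped and another, elsewhere, hurt. The expected step of a 3.1-fold higher number from compound 3 to compound 4 (0.49 log units; beyond the scatter) is therefore a modest rise, with wide uncertainty. Compound 4 is estimated at 15 nM, between 4 nM and 60 nM.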

Compound 4, half-maximal inhibitory concentration: 44 nM
The estimate for compound 4 lay 2.9-fold (0.47 log units) below the measured number; the measured number falls inside the stated range.
By their numbers in this assay, from the lowest: compound 3; then compounds 1 and 4 (each within the scatter of the next); then compound 2.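

The rise of a 9.2-fold higher number from compound 3 to compound 4 (0.96 log units; beyond the scatter) shows that the gain seen with bromo does not carry over to every group at this place. Against plain hydrogen, acetyl gives a 1.4-fold higher number from compound 1 to compound 4 (0.14 log units; within the scatter) and so keeps none of that gain, even though it is the larger group by heavy atoms. No measurement at hand says why the two groups differ. Still open, on these data alone, is how chloro, methoxy, an amine or a carboxylic acid would behave at this place. Also open, as far as these compounds go, is whether bromo would give the same gain elsewhere on the ring.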